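Swapping the ring amine for an open chain in compound 4

The compounds below may be only part of what the source reports. "The series", "measured", "known", "first", "only" and "open" are said of these compounds alone.

Measured compounds, with their growth-inhibition values in a functional assay on MDA-MB-468 cells (Homo sapiens) for cytotoxicity, read by sulforhodamine B assay, with a stated time of 48 h; on this read-out lower numbers stand for stronger inhibition of growth and higher numbers for weaker inhibition of growth:
compound 1, `Cc1ccc2nc(/N=C3\C(=O)N(CN4CCCCC4)c4cccc(Br)c43)sc2c1`, 24000 nM
compound 2, `CCN(CC)CN1C(=O)C(=O)c2c(Br)cccc21`, 11700 nM
compound 3, `Cc1ccc2nc(/N=C3\C(=O)N(CN4CCCCC4)c4cccc(Cl)c43)sc2c1`, 19800 nM

Compound 3 holds the middle number of the three. Within the data shown here, the one measured step is a 1.2-fold lower number from compound 1 to compound 3 (0.08 log units; within the scatter), and the gap from compound 3 to compound 2 is also within the usual scatter, so the three compounds cannot be ranked against each other on these numbers.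

Compound 4, `CCN(CC)CN1C(=O)/C(=N\c2nc3ccc(C)cc3s2)c2c(Cl)cccc21`, is the next step from compound 3: diethylamino in place of piperidin-1-yl on a saturated chain carbon bound to an amide-type nitrogen in a ring. Among the measured compounds shown here, no measured step matches this change. For the measured compounds named here, the one measured step, a 1.2-fold lower number from compound 1 to compound 3 (0.08 log units; within the scatter), concerns a halogen and says nothing about the amine. Compound 2 carries the same diethylamino group as compound 4, but its core differs from that of compound 3 in more than one place, so only its value can be noted, and that value lies within the scatter of compound 3.

With nothing pointing either way, the expectation is a step of no size beyond the scatter, a 1.2-fold lower number from compound 3 to compound 4 (0.07 log units; within the scatter). Compound 4 is therefore estimated at 17000 nM in this assay, with a range from 8000 nM to 40000 nM.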

Compound 4, concentration for 50% growth inhibition: 27300 nM
Compound 4: middle estimate off by 1.6-fold (0.21 log units), on the low side; the measured number falls inside the stated range.
By their numbers in this assay, from the lowest: compounds 2, 3, 1 and 4 (each within the scatter of the next, the first and the last beyond it).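

In this assay the change from the piperidin-1-yl ring to the open diethylamino group, on a saturated chain carbon bound to an amide-type nitrogen in a ring, gives a 1.4-fold higher number from compound 3 to compound 4 (0.14 log units; within the scatter) and so stays within the usual scatter of repeated measurements. Among these compounds, this is the first readable step at this position, since the earlier step concerned only the halogen, and it shows that in this pair giving up the ring, and going from 6 heavy atoms to 5, leaves no clear mark on growth inhibition. Nothing shown explains why the two amines read alike.

Still open, from the compounds shown here alone, is whether a morpholin-4-yl group, which puts an oxygen into the six-membered ring, or a longer chain on the nitrogen, such as dipropylamino, would move the number beyond the scatter at this same place. Going by these compounds, the pair also rests on a single cell line, so whether the two amines stay level in other cells remains unknown.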